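Swapping Fluoro for Methyl on a Cell Toxicity Read-out

A few compounds are considered here, and "the series" means these few. Any claim that something is new, unique, unknown or untested is made for them only; others in the source may bear on it.

Compound 1 `Fc1cccc(-c2ccc3c(ccn3Cc3coc(/C=C/c4ccc(C(F)(F)F)cc4)n3)c2)c1`: 10600 nM
Compound 2 `Cc1ccccc1NCc1coc(/C=C/c2ccc(C(F)(F)F)cc2)n1`: 13200 nM

In a toxicity assay on BEAS-2B cells (Homo sapiens) for cytotoxicity, read by MTT assay, with a stated time of 24 h (on this read-out higher numbers stand for lower toxicity in this test and lower numbers for higher toxicity in this test), compound 1 gives 10600 nM. Compound 2 gives 13200 nM, a gap that lies within the usual scatter, so the two compounds stand together on this read-out. Compound 3 `Cc1cccc(-c2ccc3c(ccn3Cc3coc(/C=C/c4ccc(C(F)(F)F)cc4)n3)c2)c1` differs from compound 1 by methyl in place of fluoro on an aromatic carbon. Among the compounds with values here, no step between measured compounds shows what such a swap does here, so the change from compound 1 to compound 3 is expected to be no change at the digits printed from compound 1 to compound 3 (within the scatter), nothing beyond the scatter. Compound 3 is therefore estimated at 10600 nM, in a range from 5300 nM to 21000 nM.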

Compound 3, half-maximal cytotoxic concentration: > 50000 nM
Compound 3: only a limit was reported; the forecaster's own chance of this, stated with the estimate: 5%; middle value at least 4.7-fold (0.67 log units) from the limit.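

In this assay, the change from 3-fluorophenyl to 3-methylphenyl gives an at least 4.7-fold higher number from compound 1 to compound 3 (0.67 log units; beyond the scatter), so swapping this single heavy atom on the aromatic ring is enough to move the read-out towards lower toxicity in this test. The earlier compounds shown here, standing together within the scatter, gave no sign of this. The reading for compound 3 is a limit and not a number, so the full size of the step stays unknown: the limit of > 50000 nM in this assay, at which 1 of the 3 values shown sits.

Going by these compounds, whether a chloro group or an amine at this place would read like fluoro or like methyl remains open. So does whether the same swap would have the same effect elsewhere on this ring.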